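Methylating the Indazole Nitrogen: a Step Without Precedent

The source may hold more compounds than are shown below. What is called first, only, known or untested is meant among the compounds shown, and "the series" means these compounds.

Three measured compounds share one core and differ only in the aryl group on the pyrazole nitrogen. In an assay on CHO-K1 cells for antagonist activity at transient receptor potential cation channel subfamily V member 1 (Homo sapiens), read by FLIPR and calcium flux, with a stated time of 6 min (a higher number here means a weaker inhibitor, a lower number a stronger inhibitor), compound 1 `CC(C)(C)c1cc(CNC(=O)Nc2cccc3[nH]ncc23)n(-c2cccc(F)c2)n1` gives 1.3 nM, compound 2 `CC(C)(C)c1cc(CNC(=O)Nc2cccc3[nH]ncc23)n(-c2ccc(F)c(F)c2)n1` gives 0.5 nM, and compound 3 `CC(C)(C)c1cc(CNC(=O)Nc2cccc3[nH]ncc23)n(-c2ccc(F)c(Cl)c2)n1` gives 0.5 nM. The steps are small: a 2.6-fold lower number from compound 1 to compound 2 (0.41 log units; beyond the scatter), a 2.6-fold lower number from compound 1 to compound 3 (0.41 log units; beyond the scatter), and no change at the digits printed from compound 2 to compound 3 (within the scatter). Compound 3 therefore stands level with compound 2, the two together at the lowest numbers of the three, with compound 1 a little higher.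

Compound 4 `Cn1ncc2c(NC(=O)NCc3cc(C(C)(C)C)nn3-c3ccc(F)c(Cl)c3)cccc21` keeps the whole of compound 3 and changes only the fused ring: methyl in place of hydrogen on an aromatic nitrogen. Among the measured compounds shown here, none of the measured steps touches this part of the molecule; all three concern the aryl group on the other ring, so nothing measured here says how this assay answers to a change at the indazole nitrogen. Without a guide, the expectation is a modest step, if any, toward a higher number, and the estimate for compound 4 is 3 nM, between 0.5 nM and 20 nM, which means an expected 6.0-fold higher number from compound 3 to compound 4 (0.78 log units; beyond the scatter).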

Compound 4, inhibition constant: 0.6 nM
Compound 4: the middle estimate sits 5.0-fold (0.70 log units) above what was measured; low and high end bracket the measured number.
By their numbers in this assay, from the lowest: compounds 2, 3 and 4 (each within the scatter of the next); then compound 1.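

In this assay, this first change at the indazole nitrogen gives a 1.2-fold higher number from compound 3 to compound 4 (0.08 log units; within the scatter), so the step is within the usual scatter of repeated measurements. On the core of compound 3, then, a methyl can stand in place of the hydrogen on this aromatic nitrogen with no measurable change in the number, which the changes to the aryl group could not show. The evidence at hand offers no explanation for this result.

From the compounds shown here alone, this is a single pair, so it remains open whether the same methyl would leave the number unchanged with the other aryl groups, those of compound 1 and compound 2. Going by these compounds, it also remains open how the assay would answer a larger group on this nitrogen, such as an ethyl, a longer chain, or a chain ending in an amine or a carboxylic acid.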